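The source may hold more compounds than are shown below. What is called first, only, known or untested is meant among the compounds shown, and "the series" means these compounds.

Compound 1 `Cn1nc(-c2ccc(OC[C@H]3CC[C@H](N)CC3)c(F)c2)c2cnc(N)nc21` is one of three antagonists of the shared core that were tested in an assay on THP-1 cells for antagonist activity at Toll-like receptor 8 (Homo sapiens); on this read-out higher numbers stand for weaker inhibition and lower numbers for stronger inhibition. In this assay compound 1 gives 5 nM. Among the two plain numbers in the set this is the higher one, and the nearest neighbour, compound 2 `Cc1cc(-c2nn(C)c3nc(N)ncc23)cnc1OCC12CCC(N)(CC1)CC2`, gives 1 nM, a gap that lies beyond the usual scatter of the measurement. Compound 3 `Cc1cc(-c2ccnc3[nH]ncc23)cnc1OCC12CCC(O)(CC1)CC2` reaches only a limit of the assay, < 1 nM, so that no number can be set against it; it is one of the values that sit at the limit described as the limit of < 1 nM in this assay, at which 1 of the 3 values shown sits.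

Compound 4 `Cn1nc(-c2ccc(OCC3CC4(CNC4)C3)c(F)c2)c2cnc(N)nc21` is a variant of compound 1 that has not yet been measured in this assay. It differs from compound 1 in the substituent on the ether side: a group of 7 heavy atoms (6 carbon, 1 nitrogen; one four-membered non-aromatic ring of carbon only, one four-membered non-aromatic ring with 1 hetero atom) in place of a group of 7 heavy atoms (6 carbon, 1 nitrogen; one six-membered non-aromatic ring of carbon only), on a saturated chain carbon bound to an oxygen on an aromatic ring. The group that leaves and the group that enters are of the same size in heavy atoms and carry the same count of donors and acceptors, and each holds one nitrogen, so the change keeps the basic amine while rearranging the rings that hold it.

Among the measured compounds shown here, no measured pair in the set shows this exact change, so the step from compound 1 to compound 4 is expected to be small, at a 1.6-fold higher number from compound 1 to compound 4 (0.20 log units; within the scatter), in either direction, and not far outside the scatter of repeated measurements. Compound 4 is therefore estimated to give 8 nM in this assay, with a likely range from 2 nM to 30 nM.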

Compound 4, half-maximal inhibitory concentration: 10 nM
Compound 4: the middle estimate sits 1.3-fold (0.10 log units) below what was measured; the measured number falls inside the stated range.
By their numbers in this assay, from the lowest: compound 2; then compounds 1 and 4 (each within the scatter of the next).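

Among the compounds shown here, with this result the set gains its only readable step between two measured compounds that differ in one place: in this assay, on a saturated chain carbon bound to an oxygen on an aromatic ring, the exchange gives a 2.0-fold higher number from compound 1 to compound 4 (0.30 log units; within the scatter). The 4-aminocyclohexyl group, with its one six-membered ring of carbon only and its 2 defined stereocentres, can thus give way to a group with no defined stereocentres, built from a four-membered ring of carbon only and a four-membered ring with 1 hetero atom, without a difference beyond the scatter of the measurement. Nothing measured here accounts for this outcome.

The compounds shown leave open how a hydroxyl group in place of the amine, or an open-chain amine in place of the rings, would read at this place in this assay. They also leave open whether the same exchange would read alike on the core of compound 2, as this single step comes from the core of compound 1 alone.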